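The compounds below may be only part of what the source reports. "The series", "measured", "known", "first", "only" and "open" are said of these compounds alone.

Among the compounds with values here, compound 1 `CN(C)c1ccc(Nc2nccc(-c3ccco3)n2)cc1` gives 1900 nM in a functional assay for inhibition, with Homo sapiens as the target (on this read-out higher numbers stand for weaker inhibition and lower numbers for stronger inhibition), the lowest of the two numbers measured so far. Compound 2 `CCN(CC)c1ccc(Nc2nccc(-c3ccco3)n2)cc1` gives 8700 nM, and the step of a 4.6-fold higher number from compound 1 to compound 2 (0.66 log units; beyond the scatter) came with diethylamino in place of dimethylamino on an aromatic carbon. Compound 3 `CN(C)c1ccc(Nc2nccc(-c3ccncc3)n2)cc1` differs from compound 1 at another place: pyridin-4-yl in place of furan-2-yl on an aromatic carbon. Within the data shown here, no measured step touches this part of the shared core, so the direction is open, and for compound 3 no step beyond the scatter is expected, no change at the digits printed from compound 1 to compound 3 (within the scatter). Compound 3 is therefore estimated at 1900 nM, with a range from 500 nM to 8000 nM.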

Compound 3, half-maximal inhibitory concentration: 3700 nM
Compound 3: middle estimate off by 1.9-fold (0.29 log units), on the low side, and the stated range covers the measured number.
By their numbers in this assay, from the lowest: compounds 1 and 3 (each within the scatter of the next); then compound 2.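

This first change at the position next to the ring nitrogen replaces the five-membered furan-2-yl with the six-membered pyridin-4-yl. In this assay, it gives a 1.9-fold higher number from compound 1 to compound 3 (0.29 log units; within the scatter), so this swap of aromatic rings, with oxygen exchanged for nitrogen as the hetero atom, leaves the number within the usual scatter. Nothing available here explains why the two groups read alike. Phenyl, with no ring hetero atom, or a non-aromatic ring such as morpholine might still shift the number beyond the scatter. On these data alone, whether diethylamino behaves the same alongside pyridin-4-yl also remains open.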